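This account rests on a few compounds, and the source may have more. Where it says the series, first, only, none or still open, it means among the compounds named here.

Working notes on the series. The shared core is shown by compound 1, `O=C1CS/C(=N\c2csc(-c3ccccc3)c2)N1`. In a functional assay on MDA-MB-231 cells (Homo sapiens) for cytotoxicity, read by MTT assay, with a stated time of 72 h (on this read-out higher numbers stand for weaker inhibition and lower numbers for stronger inhibition), compound 1 gives only a limit, > 50000 nM, and no number. Compound 2, `COc1cccc(N2C(=O)CS/C2=N\c2csc(-c3ccccc3)c2)c1`, carries an additional substituent on the core of compound 1. In this assay compound 2 is recorded as "not determined" (no result reported), so no single number is available for it. Of the two values shown for the series, one sits at the limit, (the limit of > 50000 nM in this assay, at which 1 of the 2 values shown sits); the other is blank. Among the compounds with values here, compound 2 therefore stands without a number, and the only measured neighbour offers no figure to anchor it.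

Compound 3, `COc1cccc(N2C(=O)CS/C2=N\c2csc(-c3ccc(Cl)cc3)c2)c1`, differs from compound 2 in one place: chloro in place of hydrogen on an aromatic carbon. Within the data shown here, no measured step of this kind exists, so the size and direction of the change in this assay cannot be read from data; the step from compound 2 to compound 3 is expected to be none beyond the usual scatter, in either direction. On that basis compound 3 is estimated at 30000 nM in this assay, with a range from 5000 nM to 50000 nM.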

Compound 3, half-maximal inhibitory concentration: > 50000 nM
Compound 3: a limit, no number (the forecaster's own chance of this, stated with the estimate: 50%); middle value at least 1.6-fold (0.22 log units) away from the limit.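

No new step can be read from compound 2 to compound 3. In this assay compound 3 gives only a limit, > 50000 nM, and no number. The compounds shown leave open whether phenyl to 4-chlorophenyl changes the value in this assay, and whether any compound on the shared core gives a number there at all.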